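A Methoxymethyl Group Added to Compound 1

The source may report more compounds than this note shows. Statements on the series, on what has been measured and on what is new or still open speak of the compounds shown alone.

Compound 1, `Cc1ccc2ccc(-c3cccc(C#N)c3)cc2n1`, gives 7.7 nM in a functional assay on CHO cells for inhibition of metabotropic glutamate receptor 5 (Rattus norvegicus), read by FLIPR and calcium flux; a higher number here means a weaker inhibitor, a lower number a stronger inhibitor.
Compound 2, `Cc1ccc2ccc(-c3cccc(C(F)(F)F)c3)cc2n1`, gives in this assay only a limit, > 10000 nM.

Compound 1 therefore holds the only actual number shown in this assay; the other value is a limit. Going by the values given here, the one measured step, an at least 1200-fold higher number from compound 1 to compound 2 (3.11 log units; beyond the scatter), ends at the limit of > 10000 nM in this assay, at which 1 of the 2 values shown sits. Compound 3, `COCc1cc(C#N)cc(-c2ccc3ccc(C)nc3c2)c1`, arises from compound 1 by a different change: methoxymethyl in place of hydrogen on an aromatic carbon. Among the compounds with values here, the cyano group that was swapped in the measured step remains in place in compound 3, so that step does not bear directly on this change; no measured step does. Without a comparable pair, the expected step in this assay is a 2.6-fold higher number from compound 1 to compound 3 (0.41 log units; beyond the scatter), a small shift that may not exceed the scatter. Compound 3 is thus estimated at 20 nM, with a range from 5 nM to 100 nM.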

Compound 3, half-maximal inhibitory concentration: 2 nM
Beside the measured number, compound 3's estimate is 10-fold (1.00 log units) above it; the measured number lies below the stated range.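

In this assay, methoxymethyl in place of hydrogen on an aromatic carbon gives a 3.9-fold lower number from compound 1 to compound 3 (0.59 log units; beyond the scatter), a gain beyond the scatter. The earlier step showed only how much depends on the cyano group, whereas this one concerns a different carbon of the six-membered aromatic ring, meta to a cyano group and meta to a large group. This position therefore accepts a substituent without loss, and potency even improves there, although nothing shown here accounts for the size or direction of this step.

The compounds shown leave open whether the gain needs the ether oxygen, since a plain ethyl chain, a hydroxymethyl group or an aminomethyl group at this carbon would separate that from mere added bulk. Also open, as far as these compounds go, is whether a longer ether chain or a carboxylic acid would be accepted here.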